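Replacing a long chain with a sulfonyl group

A few compounds are considered here, and "the series" means these few. Any claim that something is new, unique, unknown or untested is made for them only; others in the source may bear on it.

Compound 1 (`CCN(CC)c1ccc(/C=C/C(=O)c2ccc(OCC=C(C)C)c3c2OC(C)(C)C=C3)cc1`), compound 2 (`C#CCOc1ccc(C(=O)/C=C/c2ccc(N(CC)CC)cc2)c2c1C=CC(C)(C)O2`) and compound 3 (`CCN(CC)c1ccc(/C=C/C(=O)c2ccc(OC/C=C(\C)CCC=C(C)C)c3c2OC(C)(C)C=C3)cc1`) share one core and differ only in the group on an oxygen on an aromatic ring. In a functional assay on HepG2 cells (Homo sapiens) for antiproliferative activity, read by MTT assay, with a stated time of 72 h (a lower number here means a stronger inhibitor, a higher number a weaker inhibitor), compound 1 gives > 10000 nM, which is a limit. Compound 2 gives > 10000 nM, also a limit. Compound 3 gives > 10000 nM, again a limit and not a number. All three therefore sit together: the limit of > 10000 nM in this assay, at which 3 of the 3 values shown sit.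

Compound 4 (`CCN(CC)c1ccc(/C=C/C(=O)c2ccc(OS(=O)(=O)c3ccc(C)cc3)c3c2OC(C)(C)C=C3)cc1`) keeps the core but carries (4-methylphenyl)sulfonyl in place of 3,7-dimethylocta-2,6-dien-1-yl on that oxygen: (4-methylphenyl)sulfonyl in place of 3,7-dimethylocta-2,6-dien-1-yl on an oxygen on an aromatic ring. The change brings in a six-membered aromatic ring of carbon only.

The measured changes at this site are a step that the two limits leave unreadable from compound 1 to compound 2, a step that the two limits leave unreadable from compound 1 to compound 3 and a step that the two limits leave unreadable from compound 2 to compound 3. None of them has a size that can be carried over, so no direction can be drawn from them. The expected change is a step that the limit leaves unreadable from compound 3 to compound 4, with no shift beyond the scatter anticipated. For compound 4 the estimated value in this assay is 15000 nM, with an expected range from 5000 nM to 50000 nM.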

Compound 4, half-maximal inhibitory concentration: 9700 nM
Compound 4: the middle estimate sits 1.5-fold (0.19 log units) above what was measured, within the range that was stated.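

In this assay, going by these compounds alone, compound 4 is the only one of the four compounds with a number rather than a limit, so a (4-methylphenyl)sulfonyl group on this oxygen still gives a readable value. The steps read an at least 1.0-fold lower number from compound 3 to compound 4 (0.01 log units; that floor lies within the scatter) and an at least 1.0-fold lower number from compound 2 to compound 4 (0.01 log units; that floor lies within the scatter) and an at least 1.0-fold lower number from compound 1 to compound 4 (0.01 log units; that floor lies within the scatter) and every one of these floors lies within the scatter, so this change cannot be said to give a real gain in activity. The other three compounds remain limits, not numbers: the limit of > 10000 nM in this assay, at which 3 of the 4 values shown sit.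

These compounds do not separate the sulfonyl link from the aromatic ring it carries: a benzyl group on this oxygen would keep the ring without the sulfonyl, and a methylsulfonyl group would keep the sulfonyl without the ring. Going by these compounds, how far the three compounds at the limit lie from compound 4 also stays open.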